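The source may report more compounds than this note shows. Statements on the series, on what has been measured and on what is new or still open speak of the compounds shown alone.

Values so far, from a functional assay on RT-112 cells (Homo sapiens) for antiproliferative activity, read by MTT assay, with a stated time of 72 h (on this read-out higher numbers stand for weaker inhibition of growth and lower numbers for stronger inhibition of growth), are these:
- compound 1 `COc1cc(Nc2ncnc3c(NC(=O)Nc4ccc([N+](=O)[O-])cc4)cccc23)cc(OC)c1` gives > 20000 nM
- compound 2 `COc1cc(Nc2ncnc3c(NC(=O)Nc4cc(C)cc(C)c4)cccc23)cc(OC)c1` gives 10100 nM

Compound 1 has the reading > 20000 nM, and this is a limit of the assay and not a number. Going by the values given here, that leaves compound 2, at 10100 nM, with the only true number so far.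

The next compound, compound 3 `COc1cc(Nc2ncnc3c(NC(=O)Nc4ccc(Cl)cc4Cl)cccc23)cc(OC)c1`, has not yet been measured. It differs from compound 2 at one place, on an amide-type nitrogen whose other neighbour is the carbonyl carbon: 2,4-dichlorophenyl in place of 3,5-dimethylphenyl on an amide-type nitrogen.

Among the compounds with values here, only one measured step bears on this, a change of group on that same nitrogen: an at least 1.9-fold lower number from compound 1 to compound 2 (0.29 log units; that floor lies within the scatter). Its size is only a floor, resting on (the limit of > 20000 nM in this assay, at which 1 of the 2 values shown sits), and it gives no direction for a different pair of groups. No step beyond the scatter is therefore expected in this assay, and the assay may again report only a limit.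

The estimated step is a 1.1-fold higher number from compound 2 to compound 3 (0.04 log units; within the scatter). For compound 3 the expected value is 11000 nM, with an estimated range from 4000 nM to 25000 nM.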

Compound 3, concentration for 50% growth inhibition: 3060 nM
Compound 3: the middle estimate sits 3.6-fold (0.56 log units) above what was measured; measured number below the stated range.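

In this assay, a change of group on the amide-type nitrogen now gives a step beyond the scatter with a true number at both ends, a 3.3-fold lower number from compound 2 to compound 3 (0.52 log units; beyond the scatter), whereas the earlier step rested on a floor within the scatter. Both groups are single six-membered aromatic rings of carbon with the same count of heavy atoms and no hydrogen-bond donors or acceptors, so the read-out at this position responds to a swap that leaves those counts unchanged. The change from 4-nitrophenyl also clears the scatter, an at least 6.5-fold lower number from compound 1 to compound 3 (0.81 log units; beyond the scatter), but the size of that step is only a floor, set by a limit of the assay and not a number: the limit of > 20000 nM in this assay, at which 1 of the 3 values shown sits.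

The three compounds do not separate the effect of having chlorine on the ring from the effect of where it sits, which a 3,5-dichlorophenyl or a 4-chlorophenyl group on the same nitrogen would address. They also leave open how this position would respond to a ring bearing an amine or a carboxylic acid, since the compounds shown carry only methyl, chlorine and nitro groups there.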